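The source may report more compounds than this note shows. Statements on the series, on what has been measured and on what is new or still open speak of the compounds shown alone.

Measured so far:
- compound 1 `OC(c1ccc(Cl)cc1)(c1ccc(C(F)(F)F)cc1)c1cccnc1` at 56400 nM
- compound 2 `CC(C)c1ccc(C(O)(c2ccc(C(F)(F)F)cc2)c2cccnc2)cc1` at 56300 nM

Within the data shown here, both values come from an ADME assay on L6 cells (Rattus norvegicus) for cytotoxicity, read by resazurin assay, with a stated time of 72 h (on this read-out lower numbers stand for stronger inhibition and higher numbers for weaker inhibition), and are the only measured numbers. Compound 2 stands level with compound 1, and the two cannot be told apart within the scatter.

The next compound to be read is compound 3 `OC(c1ccc(C(F)(F)F)cc1)(c1ccc(C(F)(F)F)cc1)c1cccnc1` in the same assay. It carries trifluoromethyl in place of isopropyl on an aromatic carbon, and the change from compound 2 counts as follows: trifluoromethyl in place of isopropyl on an aromatic carbon at the same carbon.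

Among the measured compounds shown here, one measured step bears on this change. It is a 1.0-fold lower number from compound 1 to compound 2 (0.00 log units; within the scatter) for isopropyl in place of chloro at that carbon, and it lies within the scatter. For the measured compounds named here, no measured pair shows trifluoromethyl entering at this carbon, so the expectation rests on that single step. No shift beyond the scatter is expected in this assay here, and the expected step is a 1.1-fold lower number from compound 2 to compound 3 (0.03 log units; within the scatter) in this read-out. For compound 3 the estimated value is 52000 nM with an expected range from 28000 nM to 95000 nM in this assay.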

Compound 3, half-maximal inhibitory concentration: 50600 nM
For compound 3 the middle estimate is 1.0-fold (0.01 log units) above the measured one; measured number inside the range.
By their numbers in this assay, from the lowest: compounds 3, 2 and 1 (each within the scatter of the next).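

In this assay, the step of a 1.1-fold lower number from compound 2 to compound 3 (0.05 log units; within the scatter) and the step of a 1.1-fold lower number from compound 1 to compound 3 (0.05 log units; within the scatter) both stay within the scatter, so chloro, isopropyl and trifluoromethyl cannot be told apart at this carbon and no order can be set among them. Among these compounds, the earlier pair covered only two groups, and this third one extends the level reading to a swap of isopropyl, with 3 heavy atoms, for trifluoromethyl, with 4 heavy atoms, on a six-membered aromatic ring of carbon only, para to a large group. Nothing measured here explains why the three compounds read alike.

The three groups carry no net charge and have 0 hydrogen-bond donors and 0 hydrogen-bond acceptors, so these compounds leave open whether an amine, a carboxylic acid or a longer chain at this carbon would read apart from them. They also leave open how far the reading depends on the other parts of the shared core, since those parts are the same in compounds 1, 2 and 3.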